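The source may hold more compounds than are shown below. What is called first, only, known or untested is meant among the compounds shown, and "the series" means these compounds.

Compound 1 `CCOC(=O)c1ccc(-c2nn(C(C)C)c3ccccc23)cc1` and compound 2 `NC(=O)c1ccc(-c2nn(Cc3ccccc3)c3ccccc23)cc1` share a core and differ in the group on an aromatic carbon of a six-membered aromatic ring of carbon only. In a functional assay on cells (Platelet, Homo sapiens) for inhibition (a lower number here means a stronger inhibitor, a higher number a weaker inhibitor), compound 1 reaches only the limit of the assay, > 10000 nM. In this assay compound 2 likewise gives only a limit, > 10000 nM. Within the data shown here, compound 2 therefore stands at the limit of > 10000 nM in this assay, at which 2 of the 2 values shown sit, so no number of its own is known and no step between measured compounds can be read off. Compound 3 `CO/N=C\c1ccc(-c2nn(Cc3ccccc3)c3ccccc23)cc1` is the compound still to be measured: a group of 4 heavy atoms (2 carbon, 1 nitrogen, 1 oxygen; no ring) in place of a group of 3 heavy atoms (1 carbon, 1 nitrogen, 1 oxygen; no ring), on an aromatic carbon. The carbamoyl leaves and a group without a hydrogen-bond donor enters, in the same place, para to a large group. Among the measured compounds shown here, with no measured step to lean on, the step that the limit leaves unreadable from compound 2 to compound 3 is expected to be none beyond the scatter, in neither direction. Compound 3 is thus expected to give about 15000 nM in this assay, with a range from 5000 nM to 50000 nM, most probably reported again only as a limit.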

Compound 3, half-maximal inhibitory concentration: > 10000 nM
Compound 3: a limit, no number; the forecaster's own chance of this, stated with the estimate: 85%; the middle value is on the limit's open side.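

Among these compounds, compound 2 and compound 3 each give only a limit in this assay, so no step between them can be read. Compounds 1, 2 and 3 all stand at the same point: the limit of > 10000 nM in this assay, at which 3 of the 3 values shown sit.

The compounds shown leave open how strongly any of them inhibits, and whether changing the group in this place affects inhibition at all.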